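Alkyl ether length and TRPM8 agonist potency: estimating compound 4

The compounds below may be only part of what the source reports. "The series", "measured", "known", "first", "only" and "open" are said of these compounds alone.

Measured compounds:
- compound 1 `C=CCc1cc(OC)c(OC(C)C(OCCCCCCCC)c2ccc(O)c(OC)c2)c(OC)c1`: 86 nM
- compound 2 `C=CCc1cc(OC)c(OC(C)C(OCCOCCCC)c2ccc(O)c(OC)c2)c(OC)c1`: 153 nM
- compound 3 `C=CCc1cc(OC)c(OC(C)C(OC(C)C)c2ccc(O)c(OC)c2)c(OC)c1`: 82 nM

In an assay on HEK293 cells for agonist activity at transient receptor potential cation channel subfamily M member 8 (Homo sapiens), read by fluorescence and calcium flux, with a stated time of 5 min (a higher number here means that more compound is needed for the effect, a lower number that less compound is needed), compound 3 gives the lowest of the three numbers, yet its nearest neighbour compound 1 differs only as a 1.0-fold lower number from compound 1 to compound 3 (0.02 log units; within the scatter) shows, and the gap to compound 2, a 1.9-fold lower number from compound 2 to compound 3 (0.27 log units; within the scatter), is also within the scatter. Compound 4 `C=CCc1cc(OC)c(OC(C)C(OCCCCCC)c2ccc(O)c(OC)c2)c(OC)c1` differs from compound 3 by hexyl in place of isopropyl on an oxygen on a saturated carbon. The step that bears most directly on this is from compound 1 to compound 3, a 1.0-fold lower number from compound 1 to compound 3 (0.02 log units; within the scatter), where a much longer chain on the same oxygen made no difference beyond the scatter. Hexyl falls between isopropyl and octyl in length, so no step beyond the scatter is expected, a 1.0-fold higher number from compound 3 to compound 4 (0.02 log units; within the scatter). Compound 4 is therefore estimated at 85 nM, with a range from 40 nM to 180 nM.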

Compound 4, half-maximal effective concentration: 329 nM
Estimate against measurement, compound 4: 3.9-fold (0.59 log units) below; the measured number lies above the stated range.
By their numbers in this assay, from the lowest: compounds 3, 1 and 2 (each within the scatter of the next); then compound 4.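

Hexyl on this oxygen gives the first steps beyond the scatter, all modest: a 4.0-fold higher number from compound 3 to compound 4 (0.60 log units; beyond the scatter) and a 3.8-fold higher number from compound 1 to compound 4 (0.58 log units; beyond the scatter) and also a 2.2-fold higher number from compound 2 to compound 4 (0.33 log units; beyond the scatter) in this series. Chain length therefore gives no smooth trend here, since hexyl is longer than the isopropyl of compound 3 and shorter than the octyl of compound 1, yet those two lie within the scatter of each other. No measured evidence here accounts for this result. From the compounds shown here alone, whether heptyl or a longer chain such as decyl would match octyl or hexyl remains open, as does the effect of an amine at the chain end.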